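Notes on the chain terminus: tetrazole to methylsulfanyl

The source may hold more compounds than are shown below. What is called first, only, known or untested is meant among the compounds shown, and "the series" means these compounds.

Three compounds share one core and differ only at the far end of the chain on the ring oxygen. Compound 1 `CCc1cc(C(C)=O)c(O)cc1OCCCCC#N` carries a nitrile and in an assay on isolated protein for binding affinity to leukotriene B4 receptor 1 (Homo sapiens), tested at 1 uM (a lower number here means less inhibition, a higher number more inhibition at the concentration tested (going by the name of the read-out)), compound 1 gives 57%. Compound 2 `CCc1cc(C(C)=O)c(O)cc1OCCCC(C)(C)C#N` gives 46%, and the shift is a number 11 percentage points lower from compound 1 to compound 2 (beyond the scatter). Compound 3 `CCc1cc(C(C)=O)c(O)cc1OCCCC(C)(C)c1nnn[nH]1` gives 76%, the highest of the three numbers, with steps of a number 19 percentage points higher from compound 1 to compound 3 (beyond the scatter) and a number 30 percentage points higher from compound 2 to compound 3 (beyond the scatter), both beyond the scatter.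

Compound 4 `CCc1cc(C(C)=O)c(O)cc1OCCCCCCSC` has not been measured in this assay. Its change from compound 3 is 3-(methylsulfanyl)propyl in place of 1-(1H-tetrazol-5-yl)-1-methylethyl on a saturated chain carbon, three bonds along the chain from an oxygen on an aromatic ring. Both steps that reach compound 3 bear on this: the tetrazole end sits well above the nitrile ends of compound 1 and compound 2, so removing it and putting a chain with no ring in its place is expected to cost. For the measured compounds named here, no measured compound has a sulfur-bearing terminus, so the size of the loss is uncertain. The step expected is a number 31 percentage points lower from compound 3 to compound 4 (beyond the scatter), downward, landing near or below the nitrile analogues. For compound 4 the estimate in this assay is 45%, with a range from 20% to 68%.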

Compound 4, a percentage reported as inhibition, at one concentration (the size of the read-out at that concentration, not a potency): 14%
Beside the measured number, compound 4's estimate is 31 percentage points above it, and the stated range ends above it.
By their numbers in this assay, from the lowest: compound 4; then compound 2; then compound 1; then compound 3.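

In this assay, for the compounds shown here, the 3-(methylsulfanyl)propyl terminus gives the first large steps at this position: a number 62 percentage points lower from compound 3 to compound 4 (beyond the scatter), with a number 32 percentage points lower from compound 2 to compound 4 (beyond the scatter) and a number 43 percentage points lower from compound 1 to compound 4 (beyond the scatter). The earlier compounds shown here showed only modest steps, all among nitrile and tetrazole ends, whereas this result shows that the shared core with this chain end sits well under both nitrile ends, so the read-out depends heavily on the terminus and not only on the gain from the 1H-tetrazol-5-yl group. Nothing available on these compounds accounts for the size of this drop.

Compound 4 differs from compound 3 in several features at once, as the ring, the branching methyl groups and the nitrogen atoms all leave while sulfur enters, so the compounds shown cannot assign the loss to any one of these. A plain alkyl chain ending without sulfur would isolate the contribution of the sulfur atom, and a carboxylic acid in place of the 1H-tetrazol-5-yl group would show whether the high value of compound 3 is specific to the tetrazole ring.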